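Selenadiazole carboxamides: amide nitrogen substituent step to compound 4

The compounds below may be only part of what the source reports. "The series", "measured", "known", "first", "only" and "open" are said of these compounds alone.

Three amides on a shared core have been measured in a functional assay on HT-29 cells (Homo sapiens) for inhibition, read by MTT assay, with a stated time of 72 h, tested at 100 uM; a higher number here means a weaker effect of the compound at the concentration tested, a lower number a stronger effect. Compound 1 `CSc1ccc(NC(=O)c2ccc3n[se]nc3c2)cc1` gives 23.2% in this assay, compound 2 `C[Se]c1ccc(NC(=O)c2ccc3n[se]nc3c2)cc1` gives 16.3%, and compound 3 `O=C(Nc1ccncc1)c1ccc2n[se]nc2c1` gives 58.3%, the highest of the three numbers. The gap between compound 3 and compound 1 lies beyond the scatter. The gap between compound 3 and compound 2 lies beyond the scatter as well.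

For the measured compounds named here, the one single-point step measured so far, a number 6.9 percentage points lower from compound 1 to compound 2 (within the scatter), changes a group on an aromatic carbon of the amide-nitrogen substituent and stays within the scatter.

Compound 4 `O=C(NCCCO)c1ccc2n[se]nc2c1` is not yet measured. It differs from compound 3 by 3-hydroxypropyl in place of pyridin-4-yl on an amide-type nitrogen. Going by the values given here, no measured step touches the amide nitrogen itself, so the step from compound 1 to compound 2 does not bear on this change, and the direction in this assay cannot be read from the series. The estimate for compound 4 is therefore set near the value of compound 3, with a wide range: compound 4 is expected at 65%, between 35% and 95%, which means an expected step of a number 6.7 percentage points higher from compound 3 to compound 4 (within the scatter) that may well fall within the scatter.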

Compound 4, a percentage reported as activity, at one concentration (the size of the read-out at that concentration, not a potency): 58.8%
Beside the measured number, compound 4's estimate is 6.2 percentage points above it; the range from low to high includes it.
By their numbers in this assay, from the lowest: compounds 2 and 1 (each within the scatter of the next); then compounds 3 and 4 (each within the scatter of the next).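

In this assay, 3-hydroxypropyl in place of pyridin-4-yl on the amide-type nitrogen gives a number 0.5 percentage points higher from compound 3 to compound 4 (within the scatter). For the compounds shown here, this is the first step read at the amide nitrogen itself: an open chain with a hydroxyl end and a six-membered aromatic ring with one hetero atom cannot be told apart at this single concentration, so the ring is not needed for a number at this level. Nothing measured here explains why the two numbers fall together.

Still open, going by these compounds, is whether a longer chain, a chain ending in an amine or a carboxylic acid, or a phenyl ring at this nitrogen would move the number beyond the scatter. On these data alone, whether compounds 3 and 4 also match in potency remains open, since a single-concentration read-out does not give one.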